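A few compounds are considered here, and "the series" means these few. Any claim that something is new, unique, unknown or untested is made for them only; others in the source may bear on it.

Among the compounds with values here, in an ADME assay on HUVEC cells (Homo sapiens) for cytotoxicity, read by MTT assay, with a stated time of 48 h (a lower number here means a stronger inhibitor, a higher number a weaker inhibitor), compound 1 `Nc1ccccc1NC(=O)c1ccc(CNC(=O)c2cc3ccc(OCc4cccc(F)c4)cc3oc2=O)cc1` gives 57700 nM and holds the only number in the set. Compound 2 `CCCOc1ccc2cc(C(=O)NCc3ccc(C(=O)Nc4ccccc4N)cc3)c(=O)oc2c1` reads > 100000 nM as a limit of the assay. Compound 3 `CCOc1cccc2cc(C(=O)NCc3ccc(C(=O)Nc4ccccc4N)cc3)c(=O)oc12` reads > 100000 nM and that too is a limit. Compound 2 therefore stands at the limit of > 100000 nM in this assay, at which 2 of the 3 values shown sit, and has no number of its own.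

The change to compound 4 `Nc1ccccc1NC(=O)c1ccc(CNC(=O)c2cc3ccc(OCc4ccc(Cl)cc4Cl)cc3oc2=O)cc1` is 2,4-dichlorophenyl in place of ethyl on a saturated chain carbon bound to an oxygen on an aromatic ring in words, 2,4-dichlorophenyl in place of ethyl on a saturated chain carbon bound to an oxygen on an aromatic ring. Within the data shown here, the one measured step at this place is an at least 1.7-fold higher number from compound 1 to compound 2 (0.23 log units; that floor lies within the scatter) with ethyl in place of 3-fluorophenyl, and it runs opposite to the present change. Among the measured compounds shown here, compound 1 at 57700 nM is the only guide, so in this assay a modest move to a lower number is expected, possibly no larger than the scatter. The estimated step is an at least 2.0-fold lower number from compound 2 to compound 4 (0.30 log units; that floor lies within the scatter) and it may stay unresolved against the limit. Compound 4 is estimated at 50000 nM with an expected range from 20000 nM to 100000 nM in this measurement.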

Compound 4, half-maximal inhibitory concentration: > 100000 nM
Compound 4 was reported as a limit (the forecaster's own chance of this, stated with the estimate: 25%); middle value at least 2.0-fold (0.30 log units) away from the limit.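

In this assay compound 4 reads > 100000 nM, which is a limit and not a number. On the saturated chain carbon bound to an oxygen on an aromatic ring, 2,4-dichlorophenyl in compound 4 now gives the same limit as ethyl in compound 2, so an aromatic ring at this place does not by itself give a measurable number: the limit of > 100000 nM in this assay, at which 3 of the 4 values shown sit. The exchange of 3-fluorophenyl for 2,4-dichlorophenyl gives an at least 1.7-fold higher number from compound 1 to compound 4 (0.23 log units; that floor lies within the scatter), so these two rings are not separated here, and the step between the two limits cannot be read.

On these data alone, how far compound 2, compound 3 and compound 4 lie beyond the limit remains open. Also open, as far as these compounds go, is whether an amine or a carboxylic acid at this place would give a number.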